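The source may hold more compounds than are shown below. What is called first, only, known or untested is meant among the compounds shown, and "the series" means these compounds.

Measured compounds:
- compound 1, `N#Cc1ccccc1C1OCC(C/C=C\CCC(=O)O)C(c2cccnc2)O1`: 245 nM
- compound 2, `O=C(O)CC/C=C\CC1COC(c2ccc([N+](=O)[O-])cc2)OC1c1cccnc1`: 933 nM
- compound 3, `CC(C)(Oc1ccccc1F)C1OCC(C/C=C\CCC(=O)O)C(c2cccnc2)O1`: 166 nM

These three share one core and differ only in the group attached at one side of it. In a functional assay for inhibition, with Homo sapiens as the target (a lower number here means tighter binding, a higher number weaker binding), compound 3 and compound 1 sit within the usual scatter of each other, while compound 2 lies beyond that scatter, with a higher number than both. Among the measured compounds shown here, the one step that is measured in this set, a 3.8-fold higher number from compound 1 to compound 2 (0.58 log units; beyond the scatter), concerns a change on the saturated ring carbon, not on the chain carbon that is altered next.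

Compound 4, `CC(C)(Cc1ccccc1)C1OCC(C/C=C\CCC(=O)O)C(c2cccnc2)O1`, is yet to be measured in this assay. Compared with compound 3 it carries benzyl in place of 2-fluorophenoxy on a saturated chain carbon bound to two saturated chain carbons and a saturated ring carbon. For the measured compounds named here, no measured step touches this part of the molecule, so nothing here tells directly how such an exchange shifts the number; what the set shows is only that compound 1 and compound 3, with quite different groups, land close to one another. On that basis compound 4 is expected to stay near compound 3, with a step of a 1.3-fold higher number from compound 3 to compound 4 (0.12 log units; within the scatter), that is, no step beyond the scatter. The expected value for compound 4 is 220 nM, in a range from 60 nM to 800 nM.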

Compound 4, dissociation constant: 513 nM
For compound 4 the middle estimate is 2.3-fold (0.37 log units) below the measured one; measured number inside the range.
By their numbers in this assay, from the lowest: compounds 3 and 1 (each within the scatter of the next); then compounds 4 and 2 (each within the scatter of the next).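

In this assay the exchange on this saturated chain carbon proves large enough to read: a 3.1-fold higher number from compound 3 to compound 4 (0.49 log units; beyond the scatter) is a modest step beyond the scatter, so the position is not indifferent to which group it carries, although both groups keep one six-membered aromatic ring of carbon only. The group that leaves holds an oxygen, a fluorine and a hydrogen-bond acceptor, while the benzyl that enters is carbon only, and the larger picture shifts with it: a 2.1-fold higher number from compound 1 to compound 4 (0.32 log units; beyond the scatter) is also modest and beyond the scatter, whereas a 1.8-fold lower number from compound 2 to compound 4 (0.26 log units; within the scatter) stays within it, which places compound 4 alongside compound 2 and apart from compound 1 and compound 3. No measurement on hand explains why the number moves with this exchange.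

On these data alone, what stays open is whether the oxygen or the fluorine accounts for the step, and a plain phenoxy group or a 2-fluorobenzyl group on this carbon would separate the two. How an amine or a longer carbon chain in the same place would behave also remains an open question.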